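Dimethoxy for Propoxy at a Cytotoxicity Limit

The source may hold more compounds than are shown below. What is called first, only, known or untested is meant among the compounds shown, and "the series" means these compounds.

Three compounds have been examined in an ADME assay on Vero cells (Chlorocebus sabaeus) for cytotoxicity, read by MTT assay, with a stated time of 72 h; on this read-out higher numbers stand for lower toxicity in this test and lower numbers for higher toxicity in this test. Compound 1, `CC(C)Cc1ccc(C(=O)/C=C/c2ccc(C(=O)O)cc2)cc1`, gives < 10 ug/mL, which is a limit of the assay rather than a number. Compound 2, `CCCOc1ccc(C(=O)/C=C/c2ccc(C(=O)Nc3cccc(-c4cc(C(=O)OC)no4)c3)cc2)cc1`, gives > 40 ug/mL, again a limit of the assay and not a number. Compound 3, `CCOC(=O)c1cc(-c2cccc(NC(=O)c3cccc(C(F)(F)F)c3)c2)on1`, gives "not determined" (no result reported). Compound 2 thus stands at the less toxic edge of what has been seen, with one other value at the opposite limit (the limit of < 10 ug/mL in this assay, at which 1 of the 3 values shown sits; (the limit of > 40 ug/mL in this assay, at which 1 of the 3 values shown sits)) and one entry without a number.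

Compound 4, `COC(=O)c1cc(-c2cccc(NC(=O)c3ccc(/C=C/C(=O)c4ccc(OC)cc4OC)cc3)c2)on1`, is the next compound for this assay. It differs from compound 2 in one place: 2,4-dimethoxyphenyl in place of 4-propoxyphenyl on a carbonyl carbon. Among the compounds with values here, no step between two measured compounds is available, so the size of this kind of change cannot be read from the data. Compound 4 is expected to give about 45 ug/mL, in a range from 20 ug/mL to 90 ug/mL. The step that this estimate means, a step that the limit leaves unreadable from compound 2 to compound 4, is expected to stay within the scatter, with a fair chance that only a limit is reported again.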

Compound 4, half-maximal cytotoxic concentration: > 50 ug/mL
Compound 4 gave a limit, no number; the forecaster's own chance of this, stated with the estimate: 65%; middle value at least 1.1-fold (0.04 log units) away from the limit.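

Within the data shown here, compound 2 and compound 4 are both reported as limits in this assay, and no step between them can be read. The compounds shown leave open how large either half-maximal cytotoxic concentration is, and whether 2,4-dimethoxyphenyl in place of 4-propoxyphenyl shifts it at all.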